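Sulfonyl aryl swap at compound 3: expectation for compound 4

A few compounds are considered here, and "the series" means these few. Any claim that something is new, unique, unknown or untested is made for them only; others in the source may bear on it.

Measured compounds in a functional assay on the whole organism (strain Jcl:Sprague-Dawley) for inhibition, with Rattus norvegicus as the target, with stated times of 3 min and 3 h, at a dose of 1 mg/kg by the intravenous route; on this read-out higher numbers stand for more inhibition at the one dose given (going by the name of the read-out) and lower numbers for less inhibition:
compound 1 `CNCc1cc(-c2cccnc2F)n(S(=O)(=O)c2cccs2)c1` gives 96%
compound 2 `CNCc1cc(-c2cccnc2F)n(S(=O)(=O)c2ccccn2)c1` gives 81%
compound 3 `CNCc1cn(S(=O)(=O)c2cccs2)c(-c2cccnc2F)c1F` gives 98%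

Compound 3 holds the highest of the three numbers in this assay; its gap to compound 1 is within the scatter, and only compound 2 sits beyond it.

Compound 4 `CNCc1cn(S(=O)(=O)c2cc(OC)ccn2)c(-c2cccnc2F)c1F` is the unmeasured member. It differs from compound 3 in one place: 4-methoxypyridin-2-yl in place of thiophen-2-yl on a sulfonyl sulfur.

Going by the values given here, one measured step bears on this change. The exchange of thiophen-2-yl for pyridin-2-yl on the sulfonyl sulfur gave a number 15 percentage points lower from compound 1 to compound 2 (beyond the scatter), a modest fall beyond the scatter. The step from compound 1 to compound 3, a number 2 percentage points higher from compound 1 to compound 3 (within the scatter), shows the fluoro substitution itself leaves the number essentially unchanged, so the fluoro present in both compound 3 and compound 4 should not alter the picture. Among the compounds with values here, no compound carries a 4-methoxypyridin-2-yl on the sulfonyl sulfur, so the methoxy contribution is unknown.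

Compound 4 is therefore expected to fall below compound 3 by a modest amount, a number 15 percentage points lower from compound 3 to compound 4 (beyond the scatter), giving an estimated 83% with a range from 65% to 97%.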

Compound 4, a percentage reported as inhibition, in the whole organism at one dose (the size of the read-out at that dose, not a potency): 95%
Compound 4: middle estimate off by 12 percentage points, on the low side; measured number inside the range.
By their numbers in this assay, from the lowest: compound 2; then compounds 4, 1 and 3 (each within the scatter of the next).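

In this assay, thiophen-2-yl on the sulfonyl sulfur gives way to 4-methoxypyridin-2-yl with a number 3 percentage points lower from compound 3 to compound 4 (within the scatter), so this place accepts this six-membered aromatic ring without a change beyond the scatter. That stands against a number 15 percentage points lower from compound 1 to compound 2 (beyond the scatter), the other exchange of thiophen-2-yl at this place, so leaving thiophen-2-yl does not always bring a fall beyond the scatter. No measurement is available that explains why the two exchanges differ.

The two exchanges differ in both the methoxy and the fluoro of the core, and separating these would take pyridin-2-yl on the core of compound 3 or 4-methoxypyridin-2-yl on the core of compound 1. Also open, going by these compounds, is whether 4-chloropyridin-2-yl or 4-aminopyridin-2-yl on the sulfonyl sulfur would hold the number as well.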